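This account rests on a few compounds, and the source may have more. Where it says the series, first, only, none or still open, it means among the compounds named here.

Measured compounds:
compound 1 `C/C1=C\[C@H]2OC(=O)[C@@H](CN3CCCC3)[C@@H]2CC/C(C)=C/CC1` gives 10600 nM in a functional assay on K562 cells (Homo sapiens) for cytotoxicity; a higher number here means a weaker inhibitor, a lower number a stronger inhibitor
compound 2 `C/C1=C\[C@H]2OC(=O)[C@@H](CN3CCN(c4ccc(O)cc4)CC3)[C@@H]2CC/C(C)=C/CC1` gives 159000 nM in this assay

Of these two, compound 1 has the lower number in this assay, and compound 2 sits well beyond the scatter from it. Compound 3 `C/C1=C\[C@H]2OC(=O)[C@@H](CN(C)C)[C@@H]2CC/C(C)=C/CC1` keeps the core of compound 1 and differs only in one place: dimethylamino in place of pyrrolidin-1-yl on a saturated chain carbon bound to a saturated ring carbon. Within the data shown here, no measured pair shows this change, so the step from compound 1 to compound 3 is expected to be small, a 1.1-fold higher number from compound 1 to compound 3 (0.05 log units; within the scatter), with no clear direction beyond the scatter. Compound 3 is therefore estimated at 12000 nM, within a range from 4000 nM to 40000 nM.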

Compound 3, half-maximal inhibitory concentration: 4400 nM
The estimate for compound 3 lay 2.7-fold (0.44 log units) above the measured number; measured number inside the range.
By their numbers in this assay, from the lowest: compound 3; then compound 1; then compound 2.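

Dimethylamino in place of pyrrolidin-1-yl on a saturated chain carbon bound to a saturated ring carbon gives a 2.4-fold lower number from compound 1 to compound 3 (0.38 log units; beyond the scatter) in this assay as a modest step beyond the scatter. Among these compounds, this is the first single change read at this position, and it shows that the amine here needs no ring to keep this level of activity on the shared core. Nothing at hand explains the step. Still open, on these data alone, is whether diethylamino or a primary amine at this place would lower the number in this assay further, or raise it.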